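Trimming a propyl to a methyl on a shared core

This account rests on a few compounds, and the source may have more. Where it says the series, first, only, none or still open, it means among the compounds named here.

Of the compounds shown here, two have been measured here. Compound 1 `[O-][S+](Cc1ccccc1)c1nnc(-c2ccccc2O)o1` gives 6000 nM in a functional assay on HUVEC cells (Homo sapiens) for inhibition, read by ELISA; a lower number here means a stronger inhibitor, a higher number a weaker inhibitor. Compound 2 `CCCc1nnc([S+]([O-])Cc2ncc(C)c(OC)c2C)o1` gives 8000 nM in this assay; this is the higher of the two numbers, but the gap to compound 1 lies within the scatter of the assay, so the two cannot be told apart. Compound 3 `COc1c(C)cnc(C[S+]([O-])c2nnc(C)o2)c1C` has not yet been measured. It differs from compound 2 in one place: hydrogen in place of ethyl on a saturated chain carbon bound to an aromatic carbon. The change removes part of a short chain and leaves the rest of the shared core untouched. Among the compounds with values here, no measured pair shows such a step, so there is nothing to lean on beyond the two values above. A shortening of this kind is expected to change little, perhaps weakening slightly, with the step of a 1.3-fold higher number from compound 2 to compound 3 (0.10 log units; within the scatter) expected to stay near the scatter. Compound 3 is therefore estimated at 10000 nM, most likely between 4000 nM and 30000 nM.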

Compound 3, half-maximal inhibitory concentration: 8000 nM
For compound 3 the middle estimate is 1.3-fold (0.10 log units) above the measured one; low and high end bracket the measured number.
By their numbers in this assay, from the lowest: compounds 1, 2 and 3 (each within the scatter of the next).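

Trimming the chain gives no change at the digits printed from compound 2 to compound 3 (within the scatter) in this assay, the first step measured at this position. On this shared core, then, the ethyl on the saturated chain carbon bound to an aromatic carbon can go without a change that the assay can detect, so a methyl serves as well as a propyl in this one pair. No measurement shown here explains this result.

From the compounds shown here alone, whether the number would also hold with a longer chain such as hexyl, or with a chain ending in an amine or a carboxylic acid, stays open. Also open, going by these compounds, is whether any group at this place can move the number beyond the scatter, and a single pair cannot show how this position behaves more generally.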